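This account rests on a few compounds, and the source may have more. Where it says the series, first, only, none or still open, it means among the compounds named here.

Compounds 1, 2 and 3 share a common core and were each tested in an ADME assay on MRC5 cells (Homo sapiens) for cytotoxicity, read by resazurin assay, with a stated time of 72 h; a higher number here means a weaker inhibitor, a lower number a stronger inhibitor. Compound 1 `O=[N+]([O-])c1cn2c(n1)OC(COc1cnc(-c3ccc(F)cc3)cn1)CC2` gives only a limit of the assay, > 64000 nM. Compound 2 `CC1(COc2ccc(-c3ccc(F)nc3F)nc2)CCn2cc([N+](=O)[O-])nc2O1` likewise gives only a limit, > 64000 nM. Compound 3 `CC1(CN2CCC(Oc3ccc(F)cc3)CC2)CCn2cc([N+](=O)[O-])nc2O1` also gives only a limit, > 64000 nM. Compound 3 therefore stands where the other two stand: none of the three reaches a measurable number in this assay, and the limit of > 64000 nM in this assay, at which 3 of the 3 values shown sit, sums up this shared position.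

Compound 4 `CC1(CN2CCC(c3ccc(F)cc3)CC2)CCn2cc([N+](=O)[O-])nc2O1` has not yet been measured. The change from compound 3 to compound 4 is 4-fluorophenyl in place of 4-fluorophenoxy on a saturated ring carbon. Within the data shown here, no step between two measured compounds is available in this set, so the size of the shift that this swap brings in this assay cannot be read from any measured pair. Compound 3 sits only at a limit, and compound 4 is expected to show no step beyond the usual scatter, a step that the limit leaves unreadable from compound 3 to compound 4, most likely returning a limit once more rather than a number. The estimate for compound 4 in this assay is 100000 nM, with a range from 30000 nM to 300000 nM.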

Compound 4, half-maximal inhibitory concentration: > 64000 nM
Compound 4: only a limit was reported; the forecaster's own chance of this, stated with the estimate: 85%; the middle value does not contradict the limit.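

Compound 3 and compound 4 both give only a limit in this assay, so no step can be read for 4-fluorophenyl in place of 4-fluorophenoxy. The compounds shown leave open at what concentration, if any, they would affect these cells, and whether any of them differ, for all share one position: the limit of > 64000 nM in this assay, at which 4 of the 4 values shown sit.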